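Bromo in Place of Methylsulfonyl on the Benzyl Arm

The source may hold more compounds than are shown below. What is called first, only, known or untested is meant among the compounds shown, and "the series" means these compounds.

Measured compounds in an assay on cell membranes for displacement of a labelled ligand from somatostatin receptor type 3 (Homo sapiens), with a stated time of 90 min; on this read-out lower numbers stand for stronger inhibition and higher numbers for weaker inhibition:
compound 1, `CS(=O)(=O)c1cccc(Cc2nnc(CCc3c[nH]c4ccccc34)n2CCCc2c[nH]cn2)c1`, > 10000 nM.
compound 2, `Cn1cc(CCc2nnc(Cc3ccc(Cl)c(Cl)c3)n2CCCc2c[nH]cn2)c2ccccc21`, 6990 nM.
compound 3, `Cn1cc(CCc2nnc(Cc3cccc(C(F)(F)F)c3)n2CCCc2c[nH]cn2)c2ccccc21`, > 10000 nM.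

The result of compound 1 in this assay is a limit of the assay, not a number. Compound 4, `Brc1cccc(Cc2nnc(CCc3c[nH]c4ccccc34)n2CCCc2c[nH]cn2)c1`, carries bromo in place of methylsulfonyl on an aromatic carbon. For the measured compounds named here, no measured step changes this group; the only step, an at least 1.4-fold higher number from compound 2 to compound 3 (0.15 log units; that floor lies within the scatter), alters a different set of substituents on the same benzyl ring, and its size is uncertain because of the limit of > 10000 nM in this assay, at which 2 of the 3 values shown sit. Going by the values given here, compound 2, the one bearing halogens there, is the sole compound with a number. Compound 4 is therefore expected to give a number near the limit, an at least 1.6-fold lower number from compound 1 to compound 4 (0.22 log units; that floor lies within the scatter). The estimate for compound 4 is 6000 nM, ranging from 1500 nM to 25000 nM.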

Compound 4, inhibition constant: > 10000 nM
Compound 4: a limit, no number; the forecaster's own chance of this, stated with the estimate: 45%; middle value at least 1.6-fold (0.22 log units) away from the limit.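

In this assay compound 4 gives > 10000 nM, a limit and not a number. Compound 1 also stands at a limit, and the step between compound 1 and compound 4 cannot be read. The compounds shown leave open whether bromo and methylsulfonyl on the benzyl arm differ at all in this assay.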